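The source may report more compounds than this note shows. Statements on the series, on what has been measured and on what is new or still open speak of the compounds shown alone.

Compound 1 `Oc1cccc(-c2cc(-c3cccs3)cc(-c3ccccc3O)n2)c1` is tested in a functional assay on DU-145 cells (Homo sapiens) for cytotoxicity, read by CCK-8 assay (a lower number here means a stronger inhibitor, a higher number a weaker inhibitor), where compound 1 gives 9300 nM. Compound 2 `Oc1cccc(-c2cc(-c3cccs3)cc(-c3cccc(O)c3)n2)c1` differs from it by 3-hydroxyphenyl in place of 2-hydroxyphenyl on an aromatic carbon, and in this assay compound 2 gives 1630 nM, which is a 5.7-fold lower number from compound 1 to compound 2 (0.76 log units; beyond the scatter). Compound 3 `Oc1ccccc1-c1cc(-c2ccccn2)cc(-c2ccccc2O)n1` shares the same kind of core but the difference between the two cores is not broken down here. For compound 3 this assay reports only a limit, > 50000 nM, a value that sits at the limit of > 50000 nM in this assay, at which 1 of the 3 values shown sits.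

Compound 4 `Oc1cccc(-c2cc(-c3ccccn3)cc(-c3ccccc3O)n2)c1` is not yet measured. It differs from compound 3 by 3-hydroxyphenyl in place of 2-hydroxyphenyl on an aromatic carbon; this is the same kind of change as that from compound 1 to compound 2, though the place now sits meta to a 2-hydroxyphenyl group and meta to a pyridin-2-yl group rather than meta to a 3-hydroxyphenyl group and meta to a thiophen-2-yl group. The step from compound 3 to compound 4 is expected to be an at least 2.0-fold lower number from compound 3 to compound 4 (0.30 log units; that floor lies within the scatter), a guess that rests on the change from compound 1 to compound 2 giving a 5.7-fold lower number from compound 1 to compound 2 (0.76 log units; beyond the scatter), while for compound 3 only a limit, > 50000 nM, is known, so the starting point is uncertain. Compound 4 is therefore estimated at 25000 nM, within a range from 6000 nM to 100000 nM.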

Compound 4, half-maximal inhibitory concentration: 17100 nM
Compound 4: middle estimate off by 1.5-fold (0.16 log units), on the high side; the range from low to high includes it.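

In this assay, 3-hydroxyphenyl in place of 2-hydroxyphenyl gives a lower number on both cores, and the new step, an at least 2.9-fold lower number from compound 3 to compound 4 (0.46 log units; beyond the scatter), can be set beside the earlier one, a 5.7-fold lower number from compound 1 to compound 2 (0.76 log units; beyond the scatter): the same change on two cores in this assay, a 5.7-fold lower number (0.76 log units; beyond the scatter) from compound 1 to compound 2 and an at least 2.9-fold lower number (0.46 log units; beyond the scatter) from compound 3 to compound 4; the limit leaves it open whether they differ

Compound 3 is known only as a limit, > 50000 nM.

The direction of this change therefore carries from the thiophen-2-yl core to the pyridin-2-yl core, but these two cores do not show whether its size carries as well, and two cores make no general rule for the series.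

Between the two cores themselves, pyridin-2-yl in place of thiophen-2-yl gives a 1.8-fold higher number from compound 1 to compound 4 (0.26 log units; within the scatter), so compound 1 and compound 4 cannot be told apart in this assay, and the compounds shown leave open how that swap behaves when both hydroxyphenyl groups are 3-hydroxyphenyl. They also leave open whether a 4-hydroxyphenyl group or an aminophenyl group in the same place would continue the direction seen here.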